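A few compounds are considered here, and "the series" means these few. Any claim that something is new, unique, unknown or untested is made for them only; others in the source may bear on it.

In a functional assay on SK-MEL-28 cells (Homo sapiens) for inhibition, read by sulforhodamine B assay, with a stated time of 48 h (on this read-out higher numbers stand for weaker inhibition of growth and lower numbers for stronger inhibition of growth), compound 1 `COc1ccc(-c2cc(/C=C/C(=O)c3ccc(N)cc3)[nH]n2)cc1` gives 1870 nM. Going by the values given here, compound 2 `COc1cc(-c2cc(/C=C/C(=O)c3ccc(N)cc3)[nH]n2)cc(OC)c1OC`, which carries three methoxy groups on the same ring, gives in this assay 1860 nM, so that of the two numbers known compound 2 sits level with compound 1, the two values lying within the scatter of each other. Compound 3 `COc1ccc(-c2cc(/C=C/C(=O)c3ccc(N)cc3)[nH]n2)cc1OC` differs from compound 2 by hydrogen in place of methoxy on an aromatic carbon. Since the values of compound 1 and compound 2 do not separate, the step of a 1.0-fold higher number from compound 2 to compound 3 (0.01 log units; within the scatter) is expected to stay within the scatter, in no particular direction. Compound 3 is therefore estimated at 1900 nM, with a range from 900 nM to 4000 nM.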

Compound 3, concentration for 50% growth inhibition: 2140 nM
The estimate for compound 3 lay 1.1-fold (0.05 log units) below the measured number; low and high end bracket the measured number.
By their numbers in this assay, from the lowest: compounds 2, 1 and 3 (each within the scatter of the next).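

In this assay two single-place changes on the methoxy-bearing ring can now be read: hydrogen in place of methoxy gives a 1.2-fold higher number from compound 2 to compound 3 (0.06 log units; within the scatter) and methoxy in place of hydrogen gives a 1.1-fold higher number from compound 1 to compound 3 (0.06 log units; within the scatter) on that ring. Neither change moves the number beyond the scatter, which compound 1 and compound 2, differing in more than one place, could not show on their own. Nothing at hand accounts for these small steps.

From the compounds shown here alone, it remains open whether a group other than methoxy at this place, such as a hydroxyl, an amine or a chlorine atom, would shift the number beyond the scatter. Going by these compounds, it is equally open whether a ring carrying no methoxy group at all would do so.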